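From 3-bromophenyl to 2,4-dimethylphenyl on a sulfonamide nitrogen

This account rests on a few compounds, and the source may have more. Where it says the series, first, only, none or still open, it means among the compounds named here.

Of the compounds shown here, three sharing one core have been measured in a functional assay on MCF7 cells (Homo sapiens) for antiproliferative activity, read by sulforhodamine B assay, with a stated time of 48 h; a lower number here means a stronger inhibitor, a higher number a weaker inhibitor. Compound 1 (`O=C1NCCN1c1ccc(S(=O)(=O)Nc2ccc(F)cc2)cc1`) gives 690 nM, compound 2 (`O=C1NCCN1c1ccc(S(=O)(=O)Nc2ccc(F)c(F)c2)cc1`) gives 620 nM, and compound 3 (`O=C1NCCN1c1ccc(S(=O)(=O)Nc2cccc(Br)c2)cc1`) gives 100 nM, the lowest number of the three.

Compound 4 (`Cc1ccc(NS(=O)(=O)c2ccc(N3CCNC3=O)cc2)c(C)c1`) carries 2,4-dimethylphenyl in place of 3-bromophenyl on the sulfonamide nitrogen: 2,4-dimethylphenyl in place of 3-bromophenyl on a sulfonamide nitrogen.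

All three measured steps change the group at this same place. Adding one fluoro changed little, with a 1.1-fold lower number from compound 1 to compound 2 (0.05 log units; within the scatter). Moving to 3-bromophenyl mattered more, with a 6.9-fold lower number from compound 1 to compound 3 (0.84 log units; beyond the scatter) and a 6.2-fold lower number from compound 2 to compound 3 (0.79 log units; beyond the scatter). Going by the values given here, these steps show that the group on this nitrogen can shift the number by a modest amount, but no measured compound carries a methyl group, so they offer only indirect guidance.

Among the compounds with values here, compound 3 holds the lowest number so far, and losing its 3-bromophenyl group may give back part of that gain, so a modest step towards a weaker number is expected, though a smaller step or one in the other direction remains possible. In this assay, the estimate is a 3.0-fold higher number from compound 3 to compound 4 (0.48 log units; beyond the scatter). For compound 4, the expected value is 300 nM, within an estimated range of 80 nM to 1100 nM.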

Compound 4, half-maximal inhibitory concentration: 230 nM
Beside the measured number, compound 4's estimate is 1.3-fold (0.12 log units) above it, within the range that was stated.
By their numbers in this assay, from the lowest: compound 3; then compound 4; then compounds 2 and 1 (each within the scatter of the next).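

In this assay, going by these compounds alone, 2,4-dimethylphenyl is the first group on the sulfonamide nitrogen to carry methyl groups rather than a halogen, and it lands in the middle of the series. It does not match 3-bromophenyl, with a 2.3-fold higher number from compound 3 to compound 4 (0.36 log units; beyond the scatter), yet it gives a lower number than either fluorinated group, with a 2.7-fold lower number from compound 2 to compound 4 (0.43 log units; beyond the scatter) and a 3.0-fold lower number from compound 1 to compound 4 (0.48 log units; beyond the scatter). A halogen on this ring is therefore not needed to get below the numbers of compound 1 and compound 2, although among these four compounds the bromine-bearing compound 3 still has the lowest number, and nothing measured here explains this order.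

The compounds shown leave open how much each methyl of 2,4-dimethylphenyl contributes on its own, as both change together with the loss of the bromine. They also leave open whether the lower number of compound 3 is specific to bromine, which a ring with a single methyl, a chloro group, an amine or a carboxylic acid in its place could help to test.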